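Swapping the alkyne-linked aryl group toward a methylthiazole

The compounds below may be only part of what the source reports. "The series", "measured", "known", "first", "only" and "open" are said of these compounds alone.

Measured compounds:
compound 1 `Cc1ccc(C#Cc2ccc(C(=O)N[C@H](C)C(C)(C)O)nc2)cc1` — in a functional assay on HEK293 cells for positive allosteric modulation of metabotropic glutamate receptor 5 (Rattus norvegicus), read by fluorescence and calcium flux (on this read-out higher numbers stand for larger maximal responses and lower numbers for smaller maximal responses), compound 1 gives 63.1%
compound 2 `C[C@@H](NC(=O)c1ccc(C#Cc2ccncc2)cn1)C(C)(C)O` — in this assay compound 2 gives 66.6%

Among the measured compounds shown here, compound 2 holds the higher of the two numbers so far, but its nearest neighbour, compound 1, sits only a number 3.5 percentage points higher from compound 1 to compound 2 (within the scatter), so the two are not separable in this assay. For the measured compounds named here, that one step, pyridin-4-yl in place of 4-methylphenyl on a triple-bonded carbon, is the only measured step in this set, and it changed the maximal response by an amount inside the scatter.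

Compound 3 `Cc1nc(C#Cc2ccc(C(=O)N[C@H](C)C(C)(C)O)nc2)cs1` is the next, unmeasured member. It differs from compound 2 as follows: 2-methyl-1,3-thiazol-4-yl in place of pyridin-4-yl on a triple-bonded carbon. The change again exchanges the aryl group on the triple-bonded carbon, the same place where the step from compound 1 to compound 2 acted. Because that earlier change gave a number 3.5 percentage points higher from compound 1 to compound 2 (within the scatter), the account expects no step beyond the scatter here either, so a number 1.6 percentage points lower from compound 2 to compound 3 (within the scatter) is the anticipated step. Compound 3 is therefore estimated to reach 65% in this assay, with a range from 50% to 80%.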

Compound 3, largest response reached (reported as efficacy), in percent of the reference or control that the assay uses: 66.6%
For compound 3 the middle estimate is 1.6 percentage points below the measured one; the measured number falls inside the stated range.
By their numbers in this assay, from the lowest: compounds 1, 2 and 3 (each within the scatter of the next).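

In this assay, the exchange of a six-membered aromatic ring with 1 hetero atom for a five-membered aromatic ring with 2 hetero atoms on the triple-bonded carbon gave no change at the digits printed from compound 2 to compound 3 (within the scatter) and thus no separation between the two compounds. Setting 2-methyl-1,3-thiazol-4-yl in place of 4-methylphenyl at the same place gave a number 3.5 percentage points higher from compound 1 to compound 3 (within the scatter) as well, so across these three compounds this position carries a phenyl, a pyridine or a sulfur-containing five-membered ring with maximal responses that cannot be told apart. Nothing measured here explains why these exchanges leave the read-out within the scatter.

The compounds shown leave open whether that tolerance would hold for a saturated group such as cyclohexyl on the triple-bonded carbon, or for an aryl group bearing an amine or a carboxylic acid. On these data alone, all three also share one amide side chain, so it remains open how the maximal response would answer to a longer chain there, or to the loss of its hydroxyl group.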